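Notes: chloro in place of methyl on aromatic carbon

The source may hold more compounds than are shown below. What is called first, only, known or untested is meant among the compounds shown, and "the series" means these compounds.

Of the compounds shown here, two have numbers so far in a functional assay on HCT-116 cells (Homo sapiens) for inhibition, read by MTT assay, with a stated time of 48 h; a higher number here means a weaker inhibitor, a lower number a stronger inhibitor. Compound 1 (`C[Se]c1ccc(N(C)c2nc(C3CC3)nc3ccccc23)cc1`) gives 15 nM, and compound 2 (`Cc1nc(N(C)c2ccc([Se]C#N)c(C)c2)c2ccccc2n1`) gives 13 nM. These two values lie within the scatter of each other, so compound 2 stands level with compound 1 on the numbers shown. For the measured compounds named here, the pair differs in more than one place, and the series so far offers no measured step for a single change.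

The next compound, compound 3 (`Cc1nc(N(C)c2ccc([Se]C#N)c(Cl)c2)c2ccccc2n1`), carries chloro in place of methyl on an aromatic carbon, ortho to a group of 3 heavy atoms and meta to a large group: chloro in place of methyl on an aromatic carbon.

Going by the values given here, with no measured precedent for this exchange, the expectation rests only on compound 2 at 13 nM and on the exchange being confined to one place. No change beyond the scatter is expected in this assay, and no direction can be favoured. The expected step is a 1.1-fold higher number from compound 2 to compound 3 (0.03 log units; within the scatter). The estimate for compound 3 is 14 nM, with an expected range from 5 nM to 40 nM.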

Compound 3, half-maximal inhibitory concentration: 12 nM
Compound 3: the middle estimate sits 1.2-fold (0.07 log units) above what was measured, within the range that was stated.
By their numbers in this assay, from the lowest: compounds 3, 2 and 1 (each within the scatter of the next).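

In this assay, for the compounds shown here, the first single-place step reads a 1.1-fold lower number from compound 2 to compound 3 (0.03 log units; within the scatter) and so sets chloro and methyl level at this aromatic carbon, ortho to a group of 3 heavy atoms and meta to a large group. The exchange is a narrow one: each group counts 1 heavy atom, and neither brings a ring, a hydrogen-bond donor, a hydrogen-bond acceptor or a net charge, so the level values say nothing yet about how far this position would accept a more different group. No measurement at hand offers an explanation for the result beyond the values themselves.

Still open, going by these compounds, is how a group with a hydrogen-bond donor or a charge, such as an amine or a carboxylic acid, or a longer chain such as propyl, would read at this same aromatic carbon in this assay. Also open, on these data alone, is whether chloro and methyl would stay level on the core of compound 1, which carries a cyclopropyl group on the shared core and differs from compound 2 in more than one place.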